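Adding a Methoxy Group to an Aminophenyl Enone Pyrazole

A few compounds are considered here, and "the series" means these few. Any claim that something is new, unique, unknown or untested is made for them only; others in the source may bear on it.

Measured compounds:
compound 1 `COc1ccc(-c2cc(/C=C/C(=O)c3ccc(N)cc3)[nH]n2)cc1` — 2030 nM
compound 2 `COc1ccc(C(=O)/C=C/c2cc(-c3cc(OC)c(OC)c(OC)c3)n[nH]2)cc1` — 1740 nM

Of the compounds shown here, two sharing an enone linked to a pyrazole have been measured in a functional assay on A498 cells (Homo sapiens) for inhibition, read by sulforhodamine B assay, with a stated time of 48 h; on this read-out lower numbers stand for stronger inhibition of growth and higher numbers for weaker inhibition of growth. In this assay compound 1 gives 2030 nM, the higher of the two numbers. Compound 2, in which the enone is turned round and its pyrazole carries a trimethoxyphenyl group, gives 1740 nM; the gap between compound 1 and compound 2 lies within the scatter, so the two values show no difference that can be trusted.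

Compound 3 `COc1ccc(-c2cc(/C=C/C(=O)c3ccc(N)cc3)[nH]n2)cc1OC` has not been measured. It differs from compound 1 in one place: methoxy in place of hydrogen on an aromatic carbon. Because compound 1 gives 2030 nM and compound 2 gives 1740 nM, a further methoxy group on this ring looks unlikely to move the number far. The step is expected to be small, slightly toward stronger inhibition of growth in this assay, if beyond the scatter at all. The expected step is a 1.4-fold lower number from compound 1 to compound 3 (0.13 log units; within the scatter). For compound 3 the estimated value is 1500 nM, with a range from 600 nM to 4000 nM.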

Compound 3, concentration for 50% growth inhibition: 2370 nM
For compound 3 the middle estimate is 1.6-fold (0.20 log units) below the measured one, and the stated range covers the measured number.
By their numbers in this assay, from the lowest: compounds 2, 1 and 3 (each within the scatter of the next).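

In this assay, methoxy in place of hydrogen on an aromatic carbon, ortho to a methoxy group and meta to a large group, gives a 1.2-fold higher number from compound 1 to compound 3 (0.07 log units; within the scatter), so compound 1 and compound 3 cannot be told apart. Within the data shown here, compound 1 and compound 2 differ in more than one place, so this pair is the first to isolate a single position, and it shows that this ring carbon can carry a second methoxy group with no trustworthy difference in the read-out. Nothing measured here bears on why the two values stay so close.

This is one substitution at one ring position, so it cannot show whether the position would tolerate other groups in the same way, such as a hydroxyl, a fluorine atom or a longer ether chain like ethoxy. It also leaves open how much the amine on the other aromatic ring contributes to the read-out, and whether an amide or a carboxylic acid in its place would give a value beyond the scatter.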